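The source may hold more compounds than are shown below. What is called first, only, known or untested is meant among the compounds shown, and "the series" means these compounds.

Measured in a functional assay on MDA-MB-231 cells (Homo sapiens) for antiproliferative activity, read by MTT assay, with a stated time of 72 h; a lower number here means a stronger inhibitor, a higher number a weaker inhibitor:
- Compound 1 `CCNC(=O)CCc1cccc2c1B(O)OC2`: > 100000 nM, a limit
- Compound 2 `O=C(CCc1cccc2c1B(O)OC2)Nc1nccs1`: > 100000 nM, a limit
- Compound 3 `O=C(CCc1cccc2c1B(O)OC2)Nc1cccc(Br)c1`: 720 nM

Of these three, only compound 3 gives a number rather than a limit. The steps that reach it are large: an at least 130-fold lower number from compound 1 to compound 3 (2.14 log units; beyond the scatter), and an at least 130-fold lower number from compound 2 to compound 3 (2.14 log units; beyond the scatter). Both replace the group on the amide-type nitrogen with 3-bromophenyl, but neither alters the bromo itself.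

Compound 4 `O=C(CCc1cccc2c1B(O)OC2)Nc1cccc(-c2ccccc2)c1` differs at exactly that point: phenyl in place of bromo on an aromatic carbon. Among the measured compounds shown here, no measured step tests this replacement, so no step beyond the scatter is expected in this assay, in either direction, and the uncertainty is wide. The expected step is a 1.1-fold higher number from compound 3 to compound 4 (0.05 log units; within the scatter). For compound 4 the estimated value is 800 nM, with an expected range of 150 nM to 5000 nM.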

Compound 4, half-maximal inhibitory concentration: 220 nM
Compound 4: middle estimate off by 3.6-fold (0.56 log units), on the high side; the measured number falls inside the stated range.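

Phenyl in place of bromo on an aromatic carbon gives a 3.3-fold lower number from compound 3 to compound 4 (0.51 log units; beyond the scatter) in this assay. The place, meta to a large group, therefore takes a group of 6 heavy atoms instead of 1, and the bromo is not needed for activity at the level of compound 3. The earlier compounds changed only the whole group on the amide-type nitrogen, and two of them gave no number: the limit of > 100000 nM in this assay, at which 2 of the 4 values shown sit.

Open, from the compounds shown here alone, is whether an amine or a carboxylic acid on the added phenyl would keep this lower number. Also open, going by these compounds, is whether a methyl or a methoxy in place of the phenyl would do the same.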